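Ester-linked amide variants of a lignan lactone: cytotoxicity notes

A few compounds are considered here, and "the series" means these few. Any claim that something is new, unique, unknown or untested is made for them only; others in the source may bear on it.

Measured so far:
compound 1 `COc1ccc(C[C@H]2COC(=O)[C@@H]2Cc2ccc(OCC(=O)Nc3ccc(C)cc3)c(OC)c2)cc1OC`: 228000 nM in an ADME assay on HeLa cells (Homo sapiens) for cytotoxicity, read by MTT assay; on this read-out higher numbers stand for weaker inhibition and lower numbers for stronger inhibition
compound 2 `COc1ccc(C[C@H]2COC(=O)[C@@H]2Cc2ccc(OC(=O)CCC(=O)N3CCCC3)c(OC)c2)cc1OC`: 201000 nM
compound 3 `COc1ccc(C[C@H]2COC(=O)[C@@H]2Cc2ccc(OCC(=O)N3CCCC3)c(OC)c2)cc1OC`: >= 600000 nM, which is a limit of this assay and not a number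

Compound 2 and compound 1 give numbers that sit within the scatter of each other: a 1.1-fold lower number from compound 1 to compound 2 (0.05 log units; within the scatter). Compound 3 sits at the limit of >= 600000 nM in this assay, at which 1 of the 3 values shown sits. Compound 4 `COC(=O)[C@H](CC(C)C)NC(=O)CCC(=O)Oc1ccc(C[C@H]2C(=O)OC[C@@H]2Cc2ccc(OC)c(OC)c2)cc1OC` has not yet been measured. It differs from compound 2 in one place: (1-(methoxycarbonyl)-3-methylbutyl)amino in place of pyrrolidin-1-yl on a carbonyl carbon. The measured steps that bear on this are the two into compound 3, in which pyrrolidin-1-yl on the carbonyl carbon went with a higher number: an at least 2.6-fold higher number from compound 1 to compound 3 (0.42 log units; beyond the scatter) and an at least 2.9-fold higher number from compound 2 to compound 3 (0.47 log units; beyond the scatter). The step to compound 4 runs the other way, an amino group entering in place of pyrrolidin-1-yl, so a number no higher than that of compound 2 is expected in this assay, and most likely one within the scatter of it. Compound 4 is therefore estimated at 180000 nM, with a range from 70000 nM to 500000 nM. This estimate means an expected 1.1-fold lower number from compound 2 to compound 4 (0.05 log units; within the scatter), within the scatter.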

Compound 4, half-maximal inhibitory concentration: 53200 nM
Beside the measured number, compound 4's estimate is 3.4-fold (0.53 log units) above it; the measured number lies below the stated range.
By their numbers in this assay, from the lowest: compound 4; then compounds 2 and 1 (each within the scatter of the next). At a limit, above all of these: compound 3.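

In this assay, (1-(methoxycarbonyl)-3-methylbutyl)amino in place of pyrrolidin-1-yl on a carbonyl carbon gives a 3.8-fold lower number from compound 2 to compound 4 (0.58 log units; beyond the scatter), a step beyond the scatter. The earlier steps shown here at a carbonyl carbon, both in ether-linked compounds, showed only that pyrrolidin-1-yl went with a higher number; this step shows that, in the ester-linked chain too, the group on the carbonyl carbon can shift the number, here with an open-chain group carrying a defined stereocentre and the amide hydrogen entering in place of the ring. Nothing measured here accounts for the size or direction of this step.

From the compounds shown here alone, the methoxycarbonyl, the branched side chain, the amide hydrogen and the stereocentre all change together in this one step, so the part of the entering group that goes with the lower number stays open. A carboxylic acid in place of the methoxycarbonyl, a plain unbranched alkylamino group or the opposite stereocentre would separate these features, and the same amino group on the ether-linked chain would show whether the step carries over.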